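Benzylthio nucleoside pair: aryl substituent swap

The compounds below may be only part of what the source reports. "The series", "measured", "known", "first", "only" and "open" are said of these compounds alone.

Measured so far:
compound 1 `OC[C@H]1O[C@@H](n2cnc3c(SCc4ccc(Br)cc4)ncnc32)[C@H](O)[C@@H]1O` gives 11.5 nM in an assay on isolated protein for inhibition of Equilibrative nucleoside transporter 1 (Homo sapiens); a lower number here means a stronger inhibitor, a higher number a weaker inhibitor.
compound 2 `Cc1cccc(CSc2ncnc3c2ncn3[C@@H]2O[C@H](CO)[C@@H](O)[C@H]2O)c1` gives 16.2 nM in this assay.

Compound 2 and compound 1 lie within the scatter of each other, as the step of a 1.4-fold higher number from compound 1 to compound 2 (0.15 log units; within the scatter) shows. Compound 3 `CC(C)(C)c1ccc(CSc2ncnc3c2ncn3[C@@H]2O[C@H](CO)[C@@H](O)[C@H]2O)cc1` is not yet measured; it differs from compound 2 by 4-(tert-butyl)phenyl in place of 3-methylphenyl on a saturated chain carbon bound to a sulfur. Among the compounds with values here, the only measured step bearing on this place is a 1.4-fold higher number from compound 1 to compound 2 (0.15 log units; within the scatter), which stayed within the scatter. The step expected in this assay is therefore a 1.1-fold lower number from compound 2 to compound 3 (0.03 log units; within the scatter), none beyond the scatter. Compound 3 is estimated at 15 nM, between 5 nM and 45 nM.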

Compound 3, inhibition constant: 10000 nM
Beside the measured number, compound 3's estimate is 670-fold (2.82 log units) below it; the whole stated range lies below it.
By their numbers in this assay, from the lowest: compounds 1 and 2 (each within the scatter of the next); then compound 3.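

In this assay, the earlier pair made the aryl group on a saturated chain carbon bound to a sulfur look tolerant of change, but 4-(tert-butyl)phenyl in place of 3-methylphenyl gives a 620-fold higher number from compound 2 to compound 3 (2.79 log units; beyond the scatter) at this place. On an aromatic carbon, tert-butyl in place of bromo gives an 870-fold higher number from compound 1 to compound 3 (2.94 log units; beyond the scatter), so these two groups are not interchangeable there. Nothing measured here accounts for this loss.

Still open, from the compounds shown here alone, is whether an ethyl or isopropyl group on that aromatic carbon stays near compound 1 or falls toward compound 3.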